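A few compounds are considered here, and "the series" means these few. Any claim that something is new, unique, unknown or untested is made for them only; others in the source may bear on it.

Measured so far in a functional assay on CHO cells for agonist activity at adenosine receptor A2b (Homo sapiens), read by scintillation counting and cAMP accumulation, with a stated time of 150 min, in the presence of a further agent that is not named here; a lower number here means a stronger inhibitor, a higher number a weaker inhibitor:
compound 1 `Nc1nc(NCc2cccs2)nc2sc(-c3cccs3)nc12`: 547 nM
compound 2 `Nc1nc(NCc2cccnc2)nc2sc(-c3ccco3)nc12`: 109 nM
compound 3 `Cc1ccc(-c2nc3c(N)nc(NCc4cccs4)nc3s2)o1`: 91 nM

Compound 2 holds the second highest of the three numbers. Its nearest neighbour is compound 3, and that gap lies within the scatter, so the two cannot be ordered. Compound 1 is the furthest from compound 2, and that gap lies beyond the scatter, so compound 2 reads as the lower number of that pair.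

Going by the values given here, the only step between compounds differing in one place is a 6.0-fold lower number from compound 1 to compound 3 (0.78 log units; beyond the scatter), with 5-methylfuran-2-yl in place of thiophen-2-yl on an aromatic carbon. That is a different place from the one changed here.

Compound 4 `Nc1nc(NCc2cnccn2)nc2sc(-c3ccco3)nc12` differs from compound 2 as follows: pyrazin-2-yl in place of pyridin-3-yl on a saturated chain carbon bound to a nitrogen on an aromatic ring. Among the compounds with values here, no measured step in this assay changes the group on a saturated chain carbon bound to a nitrogen on an aromatic ring, so there is no direct precedent for the size or direction of this change. With nothing measured to anchor it, the expectation is a step within the scatter, a 1.1-fold higher number from compound 2 to compound 4 (0.04 log units; within the scatter), taken as no real change. Compound 4 is therefore estimated at 120 nM, with a range from 45 nM to 320 nM.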

Compound 4, half-maximal inhibitory concentration: 13.2 nM
For compound 4 the middle estimate is 9.1-fold (0.96 log units) above the measured one; measured number below the stated range.
By their numbers in this assay, from the lowest: compound 4; then compounds 3 and 2 (each within the scatter of the next); then compound 1.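

In this assay, the saturated chain carbon bound to a nitrogen on an aromatic ring proves to be a place that responds to a small change, with an 8.3-fold lower number from compound 2 to compound 4 (0.92 log units; beyond the scatter) on going from pyridin-3-yl to pyrazin-2-yl; the earlier step, a 6.0-fold lower number from compound 1 to compound 3 (0.78 log units; beyond the scatter), lay at a different place and said nothing about this one. The two groups match in having 6 heavy atoms and one six-membered aromatic ring, and they differ in counts by 2 rather than 1 nitrogen and by 2 rather than 1 hydrogen-bond acceptors, so a swap that leaves size by heavy atoms unchanged is enough to move the number beyond the scatter. No measurement at hand accounts for this step, and this single pair cannot say which difference in the ring carries it.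

From the compounds shown here alone, it remains open whether the step carries over to a core bearing the 5-methylfuran-2-yl or thiophen-2-yl group in the other place. Also open, going by these compounds, is how a pyrimidinyl or phenyl ring, or a longer chain ahead of the pyrazin-2-yl ring, would read in this place.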